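Aryl enone pyrazoles: removing one methoxy group

The source may report more compounds than this note shows. Statements on the series, on what has been measured and on what is new or still open speak of the compounds shown alone.

Measured compounds:
compound 1 `COc1cc(-c2cc(/C=C/C(=O)c3ccc(N)cc3)[nH]n2)cc(OC)c1OC` — in a functional assay on MDA-MB-435 cells (Homo sapiens) for inhibition, read by sulforhodamine B assay, with a stated time of 48 h (on this read-out higher numbers stand for weaker inhibition of growth and lower numbers for stronger inhibition of growth), compound 1 gives 3210 nM
compound 2 `COc1ccc(C(=O)/C=C/c2cc(-c3cc(OC)c(OC)c(OC)c3)n[nH]2)cc1OC` — compound 2 gives 2710 nM
compound 3 `COc1ccc(C(=O)/C=C/c2cc(-c3cc(OC)c(OC)c(OC)c3)n[nH]2)cc1` — compound 3 gives 5690 nM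

Compound 1 and compound 2 differ in the group on the carbonyl carbon, (4-aminophenyl in place of 3,4-dimethoxyphenyl on a carbonyl carbon); the step between them is a 1.2-fold lower number from compound 1 to compound 2 (0.07 log units; within the scatter). Compound 2 and compound 3 differ by hydrogen in place of methoxy on an aromatic carbon, and that step is a 2.1-fold higher number from compound 2 to compound 3 (0.32 log units; beyond the scatter).

Compound 4 `COc1ccc(-c2cc(/C=C/C(=O)c3ccc(N)cc3)[nH]n2)cc1OC` is not yet measured. It differs from compound 1 by hydrogen in place of methoxy on an aromatic carbon. The surroundings are not identical: in compound 1 the changed carbon is also meta to a methoxy group, so this is the same kind of change as from compound 2 to compound 3, not the same change. Because a 2.1-fold higher number from compound 2 to compound 3 (0.32 log units; beyond the scatter) was observed, a similar weakening is expected here, a 2.0-fold higher number from compound 1 to compound 4 (0.31 log units; beyond the scatter). Compound 4 is therefore estimated at 6500 nM, expected to lie between 3200 nM and 13000 nM.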

Compound 4, concentration for total growth inhibition: 7230 nM
Estimate against measurement, compound 4: 1.1-fold (0.05 log units) below; the range from low to high includes it.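

Removing the methoxy group weakens growth inhibition on the core of compound 1 as well: in this assay the step is a 2.3-fold higher number from compound 1 to compound 4 (0.35 log units; beyond the scatter). Set beside the earlier step, the size of the change holds across the two cores: the same change on two cores in this assay, a 2.1-fold higher number (0.32 log units; beyond the scatter) from compound 2 to compound 3 and a 2.3-fold higher number (0.35 log units; beyond the scatter) from compound 1 to compound 4, 1.1-fold (0.03 log units) apart, within the scatter of two such steps. This supports carrying hydrogen in place of methoxy between these two cores in this one assay, but two pairs make no rule for the series, the surroundings of the changed carbon are not identical, and the data do not show why the number rises.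

The compounds shown leave open how a hydroxyl group, a fluorine atom or a longer ethoxy chain would compare with methoxy and hydrogen on that aromatic carbon.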